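A chloro substituent on the benzyl group of compound 3

A few compounds are considered here, and "the series" means these few. Any claim that something is new, unique, unknown or untested is made for them only; others in the source may bear on it.

Measured compounds:
compound 1 `CCCCc1cnc(CCc2ccc(-c3ccccc3C(=O)O)cc2)[nH]1`: 2710 nM
compound 2 `N#Cc1ccccc1Cc1cnc(CCc2ccc(-c3ccccc3C(=O)O)cc2)[nH]1`: 5480 nM
compound 3 `O=C(O)c1ccccc1-c1ccc(CCc2ncc(Cc3ccccc3)[nH]2)cc1`: 205 nM

In an in vitro functional assay on cells for agonist activity at Bombesin receptor subtype-3 (Homo sapiens), read by luminescence and calcium flux (on this read-out higher numbers stand for an effect only at larger amounts of compound and lower numbers for an effect already at smaller amounts), compound 3 gives the lowest number of the three; compound 1 is the nearest, a step of a 13-fold lower number from compound 1 to compound 3 (1.12 log units; beyond the scatter), and compound 2 the furthest, a 27-fold lower number from compound 2 to compound 3 (1.43 log units; beyond the scatter). Compound 4 `O=C(O)c1ccccc1-c1ccc(CCc2ncc(Cc3cccc(Cl)c3)[nH]2)cc1` differs from compound 3 by chloro in place of hydrogen on an aromatic carbon, that is, benzyl to 3-chlorobenzyl. Among the measured compounds shown here, no measured step tests such a change; the closest is the cyano step from compound 2 to compound 3, a 27-fold lower number from compound 2 to compound 3 (1.43 log units; beyond the scatter), which concerns a different group at a different place and so only warns that substituents on this ring can matter. Compound 4 is therefore expected to stay close to compound 3, with a step of about a 1.1-fold higher number from compound 3 to compound 4 (0.03 log units; within the scatter), within the scatter. The estimate for compound 4 in this assay is 220 nM, in a range from 60 nM to 800 nM.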

Compound 4, half-maximal effective concentration: 825 nM
Estimate against measurement, compound 4: 3.8-fold (0.57 log units) below; measured number above the stated range.
By their numbers in this assay, from the lowest: compound 3; then compound 4; then compound 1; then compound 2.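

In this assay the ring of the benzyl group in compound 3 does not take a chloro group freely: the single added atom of 3-chlorobenzyl gives a 4.0-fold higher number from compound 3 to compound 4 (0.60 log units; beyond the scatter), so with the 2-cyanophenyl compound, both substituted rings shown give higher numbers than compound 3. Even so, the ring with chloro still does better than the other two groups, with a 6.6-fold lower number from compound 2 to compound 4 (0.82 log units; beyond the scatter) and a 3.3-fold lower number from compound 1 to compound 4 (0.52 log units; beyond the scatter) as the steps. Nothing available explains the size of the chloro step. On these data alone, whether fluoro or methoxy at this place, or chloro elsewhere on the ring, would give a similar step remains open.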